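The source may report more compounds than this note shows. Statements on the series, on what has been measured and on what is new or still open speak of the compounds shown alone.

Series notes, compound 3.

The series shares one core; compound 1 `CNc1nc(-c2ccccc2)nc2c1nnn2Cc1ccccc1Cl` carries a methylamino group, and compound 2 `OCCNc1nc(-c2ccccc2)nc2c1nnn2Cc1ccccc1Cl` a (2-hydroxyethyl)amino group in its place. In an assay on isolated protein for binding affinity to adenosine receptor A1 (Bos taurus) (on this read-out lower numbers stand for stronger inhibition and higher numbers for weaker inhibition), compound 1 gives 191000000 nM and compound 2 gives 116000000 nM. Within the data shown here, the single measured step, a 1.6-fold lower number from compound 1 to compound 2 (0.22 log units; within the scatter), is within the scatter, so the two numbers show no difference that can be read. Among the measured compounds shown here, compound 2 has the lowest of the two numbers, with compound 1 as the only neighbour, within the scatter.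

Compound 3 `CCCCCCNc1nc(-c2ccccc2)nc2c1nnn2Cc1ccccc1Cl` differs from compound 2 by butyl in place of hydroxy on a saturated chain carbon, two bonds along the chain from a nitrogen on an aromatic ring. For the measured compounds named here, no measured step bears directly on this change: the one step in hand added a hydroxy to the chain and moved nothing beyond the scatter, whereas here the hydroxy leaves and butyl enters. With nothing in the data to point either way, the expected step is none beyond the scatter in this assay; compound 3 is expected to sit near compound 2, the step of a 1.3-fold higher number from compound 2 to compound 3 (0.11 log units; within the scatter) being an estimate only. Compound 3 is therefore estimated at 150000000 nM, with a range from 40000000 nM to 600000000 nM.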

Compound 3, inhibition constant: 31000000 nM
Compound 3: middle estimate off by 4.8-fold (0.68 log units), on the high side; measured number outside the range, below it.
By their numbers in this assay, from the lowest: compound 3; then compounds 2 and 1 (each within the scatter of the next).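

In this assay, among these compounds, the chain on the nitrogen on the aromatic ring now shows a readable effect: hexylamino in place of (2-hydroxyethyl)amino gives a 3.7-fold lower number from compound 2 to compound 3 (0.57 log units; beyond the scatter), the first step beyond the scatter, though a modest one. Hexylamino also separates from the methylamino group, with a 6.2-fold lower number from compound 1 to compound 3 (0.79 log units; beyond the scatter), whereas the step between the two shorter groups, a 1.6-fold lower number from compound 1 to compound 2 (0.22 log units; within the scatter), stayed within the scatter, so among these three compounds only compound 3 stands apart. No measured evidence is available to explain this step.

Hydroxy leaves and butyl enters in the same step, so the compounds shown do not separate the loss of the hydroxy from the gain in chain length; a butylamino group or a hexylamino chain ending in hydroxy would bear on that. Also open, from the compounds shown here alone, is whether a longer chain such as octyl lowers the number further, and how an amine or a carboxylic acid at the end of the chain compares with compound 3 at 31000000 nM.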